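This account rests on a few compounds, and the source may have more. Where it says the series, first, only, none or still open, it means among the compounds named here.

Three compounds have been measured in a functional assay on the whole organism for inhibition, with Rattus norvegicus as the target, read by paw edema; a higher number here means that more compound is needed for the effect, a lower number that less compound is needed:

compound 1 `O=C(O)c1cc(-n2cccc2)ccc1O`: 50 mg/kg
compound 2 `O=C(O)c1cc(C2N=NN=N2)ccc1O`: 110 mg/kg
compound 3 `O=C(O)c1cc(-n2ccnn2)ccc1O`: 150 mg/kg

Compound 2 stands second highest of the three numbers. Compound 3 sits within the scatter of it, while compound 1 needs less, a 2.2-fold higher number from compound 1 to compound 2 (0.34 log units; beyond the scatter). Compound 4 `O=C(O)c1cc(-c2ncc[nH]2)ccc1O` differs from compound 2 only in the five-membered ring on the shared core: a group of 5 heavy atoms (3 carbon, 2 nitrogen; one five-membered aromatic ring with 2 hetero atoms) in place of a group of 5 heavy atoms (1 carbon, 4 nitrogen; one five-membered non-aromatic ring with 4 hetero atoms), on an aromatic carbon. For the measured compounds named here, the steps that bear on this are the other ring swaps at the same place, a 2.2-fold higher number from compound 1 to compound 2 (0.34 log units; beyond the scatter) and a 1.4-fold higher number from compound 2 to compound 3 (0.13 log units; within the scatter), both small. A step of similar size is therefore expected for compound 4, a 1.4-fold lower number from compound 2 to compound 4 (0.14 log units; within the scatter), toward a somewhat lower number. Compound 4 is estimated at 80 mg/kg, between 40 mg/kg and 160 mg/kg.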

Compound 4, dose for half-maximal effect: 200 mg/kg
Compound 4: middle estimate off by 2.5-fold (0.40 log units), on the low side, and the stated range ends below it.
By their numbers in this assay, from the lowest: compound 1; then compounds 2, 3 and 4 (each within the scatter of the next).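

In this assay the 1H-imidazol-2-yl ring, the only ring here with a hydrogen-bond donor, cannot be told apart from the rings of the two nearest compounds (a 1.8-fold higher number from compound 2 to compound 4 (0.26 log units; within the scatter); a 1.3-fold higher number from compound 3 to compound 4 (0.12 log units; within the scatter)). The 1H-pyrrol-1-yl ring alone stands apart (a 4.0-fold higher number from compound 1 to compound 4 (0.60 log units; beyond the scatter)), so at this position compounds 2, 3 and 4 form one group and compound 1 needs less. Nothing available explains this grouping.

As far as these compounds go, whether this position needs a five-membered ring at all stays open. An amine or a carboxylic acid here could fall with either group.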